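Swapping Methoxy for Cyano on the Longer Chain

The source may report more compounds than this note shows. Statements on the series, on what has been measured and on what is new or still open speak of the compounds shown alone.

The measured compounds, each with its result in a functional assay on the whole organism with Rattus norvegicus as the target; a lower number here means that less compound is needed, a higher number that more compound is needed for the effect:
In this assay compound 1 `COc1ccccc1OCC(O)CNCC(=O)Nc1ccc(C2=NNC(=O)CC2)cc1` gives 4.6 umol/kg.
In this assay compound 2 `N#Cc1ccccc1OCC(O)CNCC(=O)Nc1ccc(C2=NNC(=O)CC2)cc1` gives 14 umol/kg.
In this assay compound 3 `COc1ccccc1OCC(O)CNCCC(=O)Nc1ccc(C2=NNC(=O)CC2)cc1` gives 4.3 umol/kg.

Compound 1 and compound 2 share one core and differ in a single place: cyano in place of methoxy on an aromatic carbon. That change produced a 3.0-fold higher number from compound 1 to compound 2 (0.48 log units; beyond the scatter), so more of compound 2 was needed than of compound 1. Compound 3 carries the other core; how it differs from compound 1 is not broken down here, and the two values of compound 1 and compound 3 lie within the usual scatter of each other.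

Compound 4 `N#Cc1ccccc1OCC(O)CNCCC(=O)Nc1ccc(C2=NNC(=O)CC2)cc1` is not yet measured. It differs from compound 3 in the same way that compound 2 differs from compound 1: cyano in place of methoxy on an aromatic carbon. Since the two descriptions of place agree word for word, this is the same change made on the second core. Among the compounds with values here, the only guide to its size is the one earlier step, a 3.0-fold higher number from compound 1 to compound 2 (0.48 log units; beyond the scatter), and there is nothing to show that the longer chain of compound 3 alters how the change plays out. Compound 4 is therefore expected to need more compound than compound 3 by a step of about a 3.0-fold higher number from compound 3 to compound 4 (0.48 log units; beyond the scatter), resting on that single measured step and on the value of compound 3 in this assay, 4.3 umol/kg. Compound 4 is estimated at 13 umol/kg, with a likely range from 7 umol/kg to 25 umol/kg.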

Compound 4, dose for half-maximal effect: 1.7 umol/kg
Estimate against measurement, compound 4: 7.6-fold (0.88 log units) above, outside the stated range (below it).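

On the core of compound 3, the swap of methoxy for cyano went the opposite way to the earlier case. In this assay there is a 2.5-fold lower number from compound 3 to compound 4 (0.40 log units; beyond the scatter), so less of the cyano compound was needed here, whereas on the core of compound 1 more of it was needed. Set side by side, the two steps point in opposite directions and lie too far apart to be dismissed as ordinary variation, which shows that the effect of this change cannot simply be carried from one core to the other in this series: the same change on two cores in this assay, a 3.0-fold higher number (0.48 log units; beyond the scatter) from compound 1 to compound 2 and a 2.5-fold lower number (0.40 log units; beyond the scatter) from compound 3 to compound 4, 7.7-fold (0.89 log units) apart, beyond the scatter of two such steps. Within the data shown here, what this does not show is why the direction reverses, and with only one pair on each core, it cannot say whether other changes on these two cores would also behave differently.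

The compounds shown leave open how the same swap would turn out on a still longer chain, which would show whether the reversal continues as the chain grows. They also leave open whether a different group in place of the methoxy, such as a chlorine atom or a methyl, would reverse between the two cores in the same way.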